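The compounds below may be only part of what the source reports. "The series", "measured", "known", "first", "only" and "open" are said of these compounds alone.

Measured so far in an assay on isolated protein for inhibition of Alpha glucosidase (Homo sapiens), with stated times of 5 min and 15 min, tested at 50 uM; a lower number here means less inhibition, a higher number more inhibition at the concentration tested (going by the name of the read-out):
compound 1 `O=C1/C(=C/c2ccccc2)CCC/C1=C\c1ccc(O)cc1` gives 53%
compound 2 `O=C1/C(=C/c2ccccc2)CCC/C1=C\c1cccc(O)c1` gives 65.1%

Compound 2 stands highest of the two numbers shown; its only neighbour is compound 1, and the single measured step is a number 12.1 percentage points higher from compound 1 to compound 2 (beyond the scatter), a modest gain beyond the scatter. Compound 3 `O=C1/C(=C/c2ccccc2)CCC/C1=C\c1ccc(O)c(O)c1` has not yet been measured in this assay. It differs from compound 2 as follows: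
hydroxy in place of hydrogen on an aromatic carbon
The entering hydroxy sits on an aromatic carbon ortho to a hydroxy group and para to a large group, so compound 3 carries both hydroxy positions that compounds 1 and 2 carry singly. Within the data shown here, no measured step isolates the addition of a second hydroxy; the one step that bears on this change is the hydroxyphenyl exchange from compound 1 to compound 2. Because of a number 12.1 percentage points higher from compound 1 to compound 2 (beyond the scatter) a step of similar modest size, or none beyond the scatter, is expected for compound 3, a number 6.9 percentage points higher from compound 2 to compound 3 (within the scatter). Compound 3 is accordingly estimated at 72%, with a range of 56% to 88%.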

Compound 3, a percentage reported as inhibition, at one concentration (the size of the read-out at that concentration, not a potency): 90.7%
Estimate against measurement, compound 3: 18.7 percentage points below; the whole stated range lies below it.
By their numbers in this assay, from the lowest: compound 1; then compound 2; then compound 3.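

In this assay, a hydroxy in place of hydrogen on an aromatic carbon raises inhibition from either singly hydroxylated compound: a number 25.6 percentage points higher from compound 2 to compound 3 (beyond the scatter), and a number 37.7 percentage points higher from compound 1 to compound 3 (beyond the scatter). Compounds 1 and 2 compared only two locations of a single hydroxy, whereas compound 3 shows that a hydroxy ortho to a hydroxy group and para to a large group adds to the inhibition already present, and that carrying both hydroxy positions gives the highest number of the three compounds. No evidence at hand bears on why this gain arises.

The compounds shown leave open whether a methoxy or an amine at this place would give a similar step, or whether the hydroxy itself is required. They also leave open how potency compares across the series, since the read-out comes from a single concentration.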